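The source may report more compounds than this note shows. Statements on the series, on what has been measured and on what is new or still open speak of the compounds shown alone.

In a physicochemical assay for lipophilicity, at pH 7.4 (on this read-out higher numbers stand for higher lipophilicity and lower numbers for lower lipophilicity), compound 3 `COc1cccc(C(=O)NCc2c(C)cc(C)[nH]c2=O)c1Cl` gives 1.2, within the scatter of compound 1 `COc1cccc(C(=O)NCc2c(C)cc(C)[nH]c2=O)c1F` at 1.4. Compound 2 `Cc1cc(C)c(CNC(=O)c2cccc(OC(C)C)c2C)c(=O)[nH]1`, at 2.1, stands higher than compound 3, beyond the scatter. Compound 4 `COc1cccc(C(=O)NCc2c(C)cc(C)[nH]c2=O)c1C` arises from compound 3 by methyl in place of chloro on an aromatic carbon, ortho to a large group and ortho to a methoxy group. For the measured compounds named here, the only measured step at this place is a number 0.20 log units lower from compound 1 to compound 3 (within the scatter), which is small. Going by the values given here, no measured pair shows methyl entering there with the rest unchanged. A step beyond the scatter in this assay is therefore not expected, in either direction. The expected step is a number 0.10 log units higher from compound 3 to compound 4 (within the scatter). In this assay compound 4 is estimated at 1.3, with an expected range from 0.9 to 1.7.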

Compound 4, distribution coefficient: 1.5
The estimate for compound 4 lay 0.20 log units below the measured number; the measured number falls inside the stated range.
By their numbers in this assay, from the lowest: compounds 3, 1 and 4 (each within the scatter of the next); then compound 2.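

In this assay, methyl on the aromatic carbon ortho to a large group and ortho to a methoxy group stays level with both halogens: a number 0.30 log units higher from compound 3 to compound 4 (within the scatter) and a number 0.10 log units higher from compound 1 to compound 4 (within the scatter). So far, the only step beyond the scatter lies at the oxygen on the aromatic ring: a number 0.60 log units lower from compound 2 to compound 4 (beyond the scatter). Nothing available accounts for the size of these steps.

Going by these compounds, it remains open whether an amine or a carboxylic acid on that aromatic carbon would give a step beyond the scatter. Also open, on these data alone, is how an ethyl group on the oxygen would compare with methyl and isopropyl.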